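Adding a Third Methoxy Group to Compound 1

The source may report more compounds than this note shows. Statements on the series, on what has been measured and on what is new or still open speak of the compounds shown alone.

Measured in a functional assay on Malme-3M cells (Homo sapiens) for cytotoxicity, read by sulforhodamine B assay, with a stated time of 48 h, tested at 0.01 uM; a higher number here means a weaker effect of the compound at the concentration tested, a lower number a stronger effect:
compound 1, `COc1ccc(C(=O)/C=C/c2cc(-c3cc(OC)c(OC)c(OC)c3)n[nH]2)cc1OC`: 95%
compound 2, `COc1ccc(C(=O)/C=C/c2cc(-c3cc(OC)c(OC)c(OC)c3)n[nH]2)cc1`: 95%
compound 3, `COc1cc(-c2cc(/C=C/C(=O)c3ccc(F)c(F)c3)[nH]n2)cc(OC)c1OC`: 93%

Compound 1 stands level with compound 2, the two together the highest of the three numbers in this assay; the nearest neighbour is compound 2, with no change at the digits printed from compound 1 to compound 2 (within the scatter), and the furthest is compound 3, with a number 2 percentage points lower from compound 1 to compound 3 (within the scatter).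

Compound 4, `COc1cc(C(=O)/C=C/c2cc(-c3cc(OC)c(OC)c(OC)c3)n[nH]2)cc(OC)c1OC`, is not yet measured. It differs from compound 1 as follows: methoxy in place of hydrogen on an aromatic carbon.

Within the data shown here, the step that bears most on this is the one from compound 1 to compound 2, where a methoxy group was removed from the same aryl ring, with no change at the digits printed from compound 1 to compound 2 (within the scatter). The other steps, a number 2 percentage points lower from compound 1 to compound 3 (within the scatter) and a number 2 percentage points lower from compound 2 to compound 3 (within the scatter), likewise stayed within the scatter. Among the measured compounds shown here, no step here has moved this assay beyond the scatter, so the added methoxy group is expected to bring no change beyond it, no change at the digits printed from compound 1 to compound 4 (within the scatter).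

Compound 4 is therefore estimated at 95%, expected between 88% and 101%.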

Compound 4, a percentage reported as activity, at one concentration (the size of the read-out at that concentration, not a potency): 100%
Compound 4: the middle estimate sits 5 percentage points below what was measured; the measured number falls inside the stated range.
By their numbers in this assay, from the lowest: compounds 3, 1, 2 and 4 (each within the scatter of the next).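

In this assay, methoxy in place of hydrogen on this aromatic carbon gives a number 5 percentage points higher from compound 1 to compound 4 (within the scatter), a step that stays within the scatter. This shows that the ring carrying the carbonyl can take a further methoxy group, ortho to a methoxy group, without a change that can be told from the scatter, just as removing a methoxy group from that ring gave none. Nothing available explains this result.

Going by these compounds, whether an amine, a carboxylic acid or a longer chain at this position would shift the number beyond the scatter remains open.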